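A few compounds are considered here, and "the series" means these few. Any claim that something is new, unique, unknown or untested is made for them only; others in the source may bear on it.

Compound 1, `Cc1cc(C)c(S(=O)(=O)NC2=NCCN2C(=S)SN2CCn3c2nsc3=S)c(C)c1`, in a functional assay on KYSE-510 cells (Homo sapiens) for antiproliferative activity, read by crystal violet staining, with a stated time of 96 h (a lower number here means a stronger inhibitor of growth, a higher number a weaker inhibitor of growth), gives >= 20000 nM.
Compound 2, `O=S(=O)(NC1=NCCN1C(=S)SN1CCn2c1nsc2=S)c1ccc(Br)cc1`, gives >= 20000 nM.
Compound 3, `O=S(=O)(NC1=NCCN1C(=S)SN1CCn2c1nsc2=S)c1ccccc1Cl`, gives >= 20000 nM.

The value of compound 1 is a limit of the assay, not a number. The value of compound 2 is likewise a limit. The value of compound 3 is likewise a limit. All three values sit at the limit of >= 20000 nM in this assay, at which 3 of the 3 values shown sit, so the three steps among them, a step that the two limits leave unreadable from compound 1 to compound 2, a step that the two limits leave unreadable from compound 1 to compound 3 and a step that the two limits leave unreadable from compound 2 to compound 3, cannot be read in size or direction. Compound 3 therefore stands nowhere distinguishable from compound 1 or compound 2 on the numbers shown: every change of the aryl group on the sulfonyl sulfur tried so far has left the value at the limit.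

Compound 4, `O=S(=O)(NC1=NCCN1C(=S)SN1CCn2c1nsc2=S)c1ccc(Cl)cc1Cl`, differs from compound 3 by chloro in place of hydrogen on an aromatic carbon, which read one bond further out is 2-chlorophenyl to 2,4-dichlorophenyl. The measured steps bear on it only in that none of them produced a readable value, so no direction can be drawn from them. The expected step of a number no higher from compound 3 to compound 4 (the limit leaves the size open) is none beyond the scatter, with the result most likely again a limit. Compound 4 is estimated at 20000 nM in this assay, within 8000 nM to 50000 nM.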

Compound 4, concentration for 50% growth inhibition: >= 20000 nM
Compound 4 gave a limit, no number; the forecaster's own chance of this, stated with the estimate: 85%; the middle value sits exactly at the limit.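

In this assay compound 4 gives >= 20000 nM, a limit of the assay and not a number. Its steps from compound 1, compound 2 and compound 3 therefore cannot be read in size or direction: the limit of >= 20000 nM in this assay, at which 4 of the 4 values shown sit. The compounds shown leave open whether any aryl group on the sulfonyl sulfur of the shared core gives a readable number in this assay.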